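A few compounds are considered here, and "the series" means these few. Any claim that something is new, unique, unknown or untested is made for them only; others in the source may bear on it.

Compound 1, with the structure `C#CCN(C)CCCOc1cc(NC(=O)CCCCCCC(=O)NO)c(Cl)cc1Cl`, was tested in an assay on isolated protein for inhibition of protein deacetylase HDAC6 (Homo sapiens), read by fluorescence (a higher number here means a weaker inhibitor, a lower number a stronger inhibitor), and gave 60 nM. Within the data shown here, of the two compounds measured so far it holds the higher number. Its companion, compound 2, with the structure `C#CCN(C)CCCOc1ccc(NC(=O)CCCCCCC(=O)NO)cc1Cl`, gave in this assay 6 nM, a lower number than that of compound 1, and the gap between the two lies beyond the usual scatter of this measurement. The two compounds differ in more than one place on the shared core, so no single change accounts for the gap.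

Compound 3, with the structure `C#CCN(C)CCCOc1cc(NC(=O)CCCCCCC(=O)NO)ccc1Cl`, has not yet been measured in this assay. It differs from compound 1 in one place:

hydrogen in place of chloro on an aromatic carbon

Among the measured compounds shown here, since no measured pair shows this change on its own, the expectation rests on the numbers of compound 1 and compound 2 alone. Compound 3 is expected to move toward the lower number of compound 2, with an estimated step of a 2.4-fold lower number from compound 1 to compound 3 (0.38 log units; beyond the scatter). Compound 3 is thus expected to give in this assay about 25 nM, within a range from 8 nM to 80 nM.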

Compound 3, half-maximal inhibitory concentration: 10 nM
Beside the measured number, compound 3's estimate is 2.5-fold (0.40 log units) above it; measured number inside the range.
By their numbers in this assay, from the lowest: compounds 2 and 3 (each within the scatter of the next); then compound 1.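

In this assay, replacing the chloro on the aromatic carbon ortho to a large group and para to the 3-(methyl(propargyl)amino)propoxy group with hydrogen gives a 6.0-fold lower number from compound 1 to compound 3 (0.78 log units; beyond the scatter), a step beyond the usual scatter. Among these compounds, this is the first change at this position that can be read on its own, since compound 1 and compound 3 differ only here, whereas the earlier pair differed in more than one place. It shows that, with the chloro group meta to this carbon present in both compounds, the chloro at this position goes with the weaker inhibition and hydrogen with the stronger, although nothing available gives a reason for the size or the direction of this step.

From the compounds shown here alone, a single pair cannot show whether this step is particular to chloro, and it remains open whether a fluoro, methyl or methoxy group on the same carbon would give a number closer to that of compound 1 or to that of compound 3. Going by these compounds, it also remains open whether the step would keep its size if the chloro group meta to this carbon gave way to hydrogen or if the hydroxamic acid chain were replaced by a longer chain.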